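The source may hold more compounds than are shown below. What is called first, only, known or untested is meant among the compounds shown, and "the series" means these compounds.

Working notes on the amide series. The shared core of compound 1 `CCc1cc(CC)n2nc(-c3ccc(OC)cc3)c(CC(=O)N(C)C)c2n1` carries a dimethylamide; in an assay on C6 cells for displacement of a labelled ligand from Translocator protein (Rattus norvegicus), read by scintillation counting, with a stated time of 2 h (a higher number here means a weaker inhibitor, a lower number a stronger inhibitor), compound 1 gives 37.6 nM. Compound 2 `CCc1cc(CC)n2nc(-c3ccc(OC)cc3)c(CC(=O)N(CC)C(C)(C)C)c2n1` gives 59.1 nM in this assay, and the step of a 1.6-fold higher number from compound 1 to compound 2 (0.20 log units; within the scatter). Compound 3 `CCc1cc(CC)n2nc(-c3ccc(OC)cc3)c(CC(=O)N(C)c3ccccc3)c2n1` gives 6.44 nM in this assay, the lowest of the three numbers; the steps into it were a 5.8-fold lower number from compound 1 to compound 3 (0.77 log units; beyond the scatter) and a 9.2-fold lower number from compound 2 to compound 3 (0.96 log units; beyond the scatter).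

Compound 4 `CCc1cc(CC)n2nc(-c3ccc(OC)cc3)c(CC(=O)N3CCC3)c2n1` is not yet measured. The change from compound 3 is azetidin-1-yl in place of methyl(phenyl)amino on a carbonyl carbon. The two steps that bear on it are the ones that brought methyl(phenyl)amino in: from compound 1 and from compound 2 the number fell by a modest amount each time. Compound 4 has no aromatic ring on the amide nitrogen, which puts it alongside compound 1 at 37.6 nM and compound 2 at 59.1 nM rather than alongside compound 3. The expected step is therefore upward, of modest size, a 4.7-fold higher number from compound 3 to compound 4 (0.67 log units; beyond the scatter). Compound 4 is expected to give 30 nM in this assay, with a range of 12 nM to 80 nM.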

Compound 4, inhibition constant in the Translocator protein assay: 87.8 nM
Estimate against measurement, compound 4: 2.9-fold (0.47 log units) below; the measured number lies above the stated range.
By their numbers in the Translocator protein assay, from the lowest: compound 3; then compounds 1, 2 and 4 (each within the scatter of the next, the first and the last beyond it).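

In the Translocator protein assay a ring on the amide nitrogen does not by itself carry the gain seen with methyl(phenyl)amino, since azetidin-1-yl in its place gives a 14-fold higher number from compound 3 to compound 4 (1.13 log units; beyond the scatter) and is the large step of the series. Azetidin-1-yl also offers no gain over the open-chain amides: the change from dimethylamino gives a 2.3-fold higher number from compound 1 to compound 4 (0.37 log units; beyond the scatter) and the change from the group in compound 2 gives a 1.5-fold higher number from compound 2 to compound 4 (0.17 log units; within the scatter). In a physicochemical assay for lipophilicity, read by HPLC, at pH 7.5 (a higher number here means a more lipophilic compound, a lower number a more polar compound), compound 3 gives 3.11 and compound 4 gives 2.58. Among these four compounds only the one with an aromatic ring on the amide nitrogen stands apart, and the same change that loses that ring also lowers the measured lipophilicity: the measured partition coefficient of compound 3, 3.11, and of compound 4, 2.58, a number 0.53 log units lower (beyond the scatter)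

One pair cannot tell whether the binding number follows the aromatic ring or the partition coefficient. A cyclohexyl or pyridyl group in place of the phenyl, with the methyl kept, would bear on that question.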